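Imidazole-nitrogen substituent series: from compound 3 to compound 4

The source may hold more compounds than are shown below. What is called first, only, known or untested is meant among the compounds shown, and "the series" means these compounds.

Compound 1 `CC(C)c1onc(-c2c(Cl)cccc2Cl)c1COc1ccc(-c2nc3ccc(C(=O)O)cc3n2Cc2ccc(F)cc2)cc1` is the reference of this set. In an assay on HEK-293T cells for antagonist activity at vitamin D3 receptor (Homo sapiens), read by a luciferase reporter, with a stated time of 24 h (a higher number here means a weaker inhibitor, a lower number a stronger inhibitor), compound 1 gives 1140 nM. Compound 2 `CC(C)c1onc(-c2c(Cl)cccc2Cl)c1COc1ccc(-c2nc3ccc(C(=O)O)cc3n2CC(C)(C)C)cc1` carries the same core and gives 861 nM in this assay; the change a 1.3-fold lower number from compound 1 to compound 2 (0.12 log units; within the scatter). Compound 3 `CCCC(CCC)n1c(-c2ccc(OCc3c(-c4c(Cl)cccc4Cl)noc3C(C)C)cc2)nc2ccc(C(=O)O)cc21` is the weakest of the three. In this assay compound 3 reaches only the limit, > 10000 nM, not a number. Accordingly the step of an at least 8.7-fold higher number from compound 1 to compound 3 (0.94 log units; beyond the scatter) and the step of an at least 11-fold higher number from compound 2 to compound 3 (1.06 log units; beyond the scatter) are both bounded only on one side, because of the limit of > 10000 nM in this assay, at which 1 of the 3 values shown sits.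

Compound 4 `CC(C)Cn1c(-c2ccc(OCc3c(-c4c(Cl)cccc4Cl)noc3C(C)C)cc2)nc2ccc(C(=O)O)cc21` is not yet measured. It differs from compound 3 by isobutyl in place of 1-propylbutyl on an aromatic nitrogen. The bearing steps are those from compound 1 and compound 2 into compound 3, where a larger branched group on the ring nitrogen lost potency beyond the scatter; the move to isobutyl reverses part of that growth. A modest recovery is therefore expected, an at least 4.0-fold lower number from compound 3 to compound 4 (0.60 log units; beyond the scatter), with compound 4 expected near 2500 nM in this assay, ranging from 800 nM to 9000 nM.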

Compound 4, half-maximal inhibitory concentration: 1180 nM
Estimate against measurement, compound 4: 2.1-fold (0.33 log units) above; measured number inside the range.
By their numbers in this assay, from the lowest: compounds 2, 1 and 4 (each within the scatter of the next). At a limit, above all of these: compound 3.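

In this assay, the isobutyl group cannot be separated from the two other groups that were measured as numbers: the data show a 1.4-fold higher number from compound 2 to compound 4 (0.14 log units; within the scatter), and a 1.0-fold higher number from compound 1 to compound 4 (0.01 log units; within the scatter). Losing a methyl from neopentyl and exchanging 4-fluorophenyl for isopropyl on the chain carbon bound to the aromatic nitrogen therefore both leave the reading within the scatter, so this position accepts an aromatic ring and a branched alkyl end alike. The one reading apart, for the 1-propylbutyl group, is a limit and not a number, and an at least 8.4-fold lower number from compound 3 to compound 4 (0.92 log units; beyond the scatter) is bounded on one side only: the limit of > 10000 nM in this assay, at which 1 of the 4 values shown sits.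

Among these compounds, only 1-propylbutyl is branched on the carbon bound to the aromatic nitrogen, and it is also the group with the longest chains, so the two features stay tied together. A 1-ethylpropyl group and a straight butyl chain on that nitrogen would pull them apart.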